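Saturating the Side Chain of Compound 1

A few compounds are considered here, and "the series" means these few. Any claim that something is new, unique, unknown or untested is made for them only; others in the source may bear on it.

Compound 1 `CCCCCCC#Cc1ccc(S(=O)(=O)Nc2cccc(-c3csc(NC(C)=O)n3)c2)cc1` is the only one of the three measured compounds for which a number, rather than a limit, is reported in a functional assay on A-375 cells (Homo sapiens) for antiproliferative activity, read by trypan blue exclusion, with a stated time of 48 h, tested at 10 uM; a higher number here means a weaker effect of the compound at the concentration tested, a lower number a stronger effect: in this assay compound 1 gives 5.8%. Compound 2 `CCCCC#Cc1ccc(S(=O)(=O)Nc2cccc(-c3csc(NC(C)=O)n3)c2)cc1` is reported in this assay at a limit of the assay, < 1%. Compound 3 `CC(=O)Nc1nc(-c2cccc(NS(=O)(=O)c3ccc(C#CCCc4ccccc4)cc3)c2)cs1` is likewise reported in this assay at a limit, < 1%. The two steps away from compound 1 are a number at least 4.8 percentage points lower from compound 1 to compound 2 (that floor lies within the scatter) and a number at least 4.8 percentage points lower from compound 1 to compound 3 (that floor lies within the scatter); between the two limit compounds the step is a step that the two limits leave unreadable from compound 2 to compound 3. What the measured values show is summed up by the limit of < 1% in this assay, at which 2 of the 3 values shown sit.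

Compound 4 `CCCCCCc1ccc(S(=O)(=O)Nc2cccc(-c3csc(NC(C)=O)n3)c2)cc1` differs from compound 1 by hexyl in place of oct-1-yn-1-yl on an aromatic carbon. Neither measured step removes the triple bond or alters the chain at the aromatic carbon; both only exchange groups further along the saturated chain, and both have floors that lie within the scatter. Within the data shown here, no measured step therefore speaks directly to the change toward compound 4, and the account expects no step beyond the scatter, a number 1.8 percentage points lower from compound 1 to compound 4 (within the scatter), with a fair chance that this assay again reports only a limit. Compound 4 is accordingly estimated at 4% in this assay, between 0.5% and 15%.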

Compound 4, a percentage reported as activity, at one concentration (the size of the read-out at that concentration, not a potency): <= 1%
Compound 4 was reported as a limit; the forecaster's own chance of this, stated with the estimate: 35%; at least 3 percentage points between middle value and limit.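

Among these compounds, compound 4 is the first change made at the aromatic carbon itself, and in this assay the exchange of oct-1-yn-1-yl for hexyl gives a number at least 4.8 percentage points lower from compound 1 to compound 4 (that floor lies within the scatter). Compounds 1, 2 and 3 all keep a triple bond outside the aromatic rings, so they could not show how the read-out behaves without one; compound 4 has none, yet it is still reported at a limit of the assay, and a chain of hexyl on this aromatic carbon is thus compatible with a read-out at that limit: the limit of <= 1% in this assay, at which 1 of the 4 values shown sits. The steps to compound 4 from compound 2 and from compound 3 run between two limits and cannot be read, so the hexyl and hex-1-yn-1-yl chains, which differ only in the triple bond, cannot be ranked against each other in this assay.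

On these data alone, with most of the values at limits, the size of any difference among compounds 2, 3 and 4 stays unknown. Also open, as far as these compounds go, is how the read-out would respond at this aromatic carbon to a much shorter chain such as ethyl, to a saturated 4-phenylbutyl chain, or to a hexyl chain ending in an amine or a carboxylic acid.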